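The compounds below may be only part of what the source reports. "The series", "measured", "known", "first", "only" and "open" are said of these compounds alone.

Three measured members of the series share one core and differ only at a single aromatic carbon. In an ADME assay (liver) for metabolic stability, with Liver microsome (Rattus norvegicus) as the target, using microsomes and NADPH, with a stated time of 30 min, tested at 1 uM (a higher number here means faster removal of the compound, a lower number slower removal), compound 1 `Nc1ccc(S(=O)(=O)N2CCN(c3ncc(C(O)(C(F)(F)F)C(F)(F)F)cc3C#CC3CC3)CC2)cn1` gives 67 mL.min-1.g-1. Compound 2 `CC(C)(O)C#Cc1cc(C(O)(C(F)(F)F)C(F)(F)F)cnc1N1CCN(S(=O)(=O)c2ccc(N)nc2)CC1` gives 16 mL.min-1.g-1 in this assay, and compound 3 `Nc1ccc(S(=O)(=O)N2CCN(c3ncc(C(O)(C(F)(F)F)C(F)(F)F)cc3-c3cccnc3)CC2)cn1` gives 20 mL.min-1.g-1 in this assay. The two alkynes differ by a 4.2-fold lower number from compound 1 to compound 2 (0.62 log units; beyond the scatter), the alkyne-to-aryl exchange by a 3.4-fold lower number from compound 1 to compound 3 (0.53 log units; beyond the scatter), while a 1.3-fold higher number from compound 2 to compound 3 (0.10 log units; within the scatter). Compound 3 therefore stands second highest of the three numbers, indistinguishable from compound 2 and separated from compound 1 only.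

Compound 4 `Nc1ccc(S(=O)(=O)N2CCN(c3ncc(C(O)(C(F)(F)F)C(F)(F)F)cc3-c3cc4ccccc4[nH]3)CC2)cn1` carries the change (1H-indol-2-yl in place of pyridin-3-yl on an aromatic carbon). Going by the values given here, no measured step exchanges one aromatic group for another at this carbon, so the bearing of the data is indirect: the one aryl replacement measured, from compound 1 to compound 3, shifted the number beyond the scatter, whereas compound 2 and compound 3 sit together. The change from compound 3 to compound 4 is smaller in kind than either, and a step of a 1.5-fold higher number from compound 3 to compound 4 (0.18 log units; within the scatter) in this assay is expected, likely not beyond the scatter, with a drift toward a higher number. Compound 4 is accordingly estimated at 30 mL.min-1.g-1, with a range from 12 mL.min-1.g-1 to 75 mL.min-1.g-1.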

Compound 4, intrinsic clearance in microsomes: 146 mL.min-1.g-1
For compound 4 the middle estimate is 4.9-fold (0.69 log units) below the measured one, and the stated range ends below it.
By their numbers in this assay, from the lowest: compounds 2 and 3 (each within the scatter of the next); then compound 1; then compound 4.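

At this aromatic carbon the identity of the aromatic group matters in this assay: 1H-indol-2-yl in place of pyridin-3-yl gives a 7.3-fold higher number from compound 3 to compound 4 (0.86 log units; beyond the scatter) in a pair where the earlier compounds had shown only that an aryl group could sit level with the hydroxylated alkyne. Set against the two alkynes, the same group gives a 9.1-fold higher number from compound 2 to compound 4 (0.96 log units; beyond the scatter) and a 2.2-fold higher number from compound 1 to compound 4 (0.34 log units; beyond the scatter), so compound 4 holds the highest number of the four, and the spread reachable through this one position is wider than the first three compounds indicated. Nothing available here accounts for this rise.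

The indole differs from pyridin-3-yl at once in its ring count, its heavy-atom count and its hydrogen-bond donor, so these compounds do not tell which of those differences goes with the higher number. Going by these compounds, a phenyl group or a 1-methyl-1H-indol-2-yl group at the same carbon would separate them, and whether the step from compound 3 to compound 4 holds on a different core also stays open.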